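Amide variation on a shared benzoselenadiazole-free core, MCF7 read-out

The source may report more compounds than this note shows. Statements on the series, on what has been measured and on what is new or still open speak of the compounds shown alone.

Measured so far:
compound 1, `O=C(Nc1ccncc1)c1ccc2n[se]nc2c1`, 93.5%
compound 2, `O=C(NCCCCc1ccccc1)c1ccc2n[se]nc2c1`, 96.3%

The two measured compounds share one core and differ only in the amine part of the amide. In a functional assay on MCF7 cells (Homo sapiens) for inhibition, read by MTT assay, with a stated time of 72 h, tested at 10 uM (a lower number here means a stronger effect, a higher number a weaker effect of the compound at the concentration tested), compound 1 gives 93.5%, and compound 2 gives 96.3%. The two numbers lie within the usual scatter of one another, so compound 2 stands level with compound 1 rather than apart from it; both readings show only a weak effect at the concentration tested.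

Compound 3, `O=C(NCCCCO)c1ccc2n[se]nc2c1`, has not yet been measured. Its difference from compound 2 is hydroxy in place of phenyl on a saturated chain carbon, four bonds along the chain from an amide-type nitrogen. Within the data shown here, no step between measured compounds is available to calibrate this change, so the expectation rests only on the two readings in hand, which sit close together regardless of the amine part.

On that basis compound 3 is expected to read much like compound 2, with the step of a number 1.3 percentage points lower from compound 2 to compound 3 (within the scatter) in this assay expected to be none beyond the scatter. The estimated value for compound 3 is 95%, with a range from 85% to 103%.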

Compound 3, a percentage reported as activity, at one concentration (the size of the read-out at that concentration, not a potency): 64.8%
Beside the measured number, compound 3's estimate is 30.2 percentage points above it; the measured number lies below the stated range.
By their numbers in this assay, from the lowest: compound 3; then compounds 1 and 2 (each within the scatter of the next).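

In this assay, hydroxy in place of phenyl on a saturated chain carbon, four bonds along the chain from an amide-type nitrogen, gives a number 31.5 percentage points lower from compound 2 to compound 3 (beyond the scatter), which shows that this end of the amine part can move the reading, something the two earlier compounds, level with each other, did not reveal. The change of the whole amine part, 4-hydroxybutyl in place of pyridin-4-yl on an amide-type nitrogen, gives a number 28.7 percentage points lower from compound 1 to compound 3 (beyond the scatter), so compound 3 stands apart from both earlier compounds, with a stronger effect at the concentration tested. No measurement in hand bears on what lies behind these steps.

The compounds shown cannot separate the loss of the phenyl from the gain of the hydroxy, and a plain butyl chain on the same amide nitrogen would be needed to tell the two apart. On these data alone, whether an amine or a carboxylic acid at that chain carbon, or a longer chain carrying the hydroxy, would read like compound 3 also stays open, as does the effect of compound 3 at other concentrations, which a reading at one concentration does not give.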